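The source may report more compounds than this note shows. Statements on the series, on what has been measured and on what is new or still open speak of the compounds shown alone.

Three sulfonamides sharing one core have been measured. Compound 3 `CCOC(=O)c1oc2ccc(NS(=O)(=O)c3ccc(Br)cc3)cc2c1C` gives 31100 nM in a functional assay on MDA-MB-231 cells (Homo sapiens) for antiproliferative activity, read by MTT assay, with a stated time of 72 h (a lower number here means a stronger inhibitor, a higher number a weaker inhibitor), and stands second highest of the three numbers; its nearest neighbour is compound 1 `CCOC(=O)c1oc2ccc(NS(=O)(=O)c3cccc(C)c3)cc2c1C` with 29500 nM, and the furthest is compound 2 `CCOC(=O)c1oc2ccc(NS(=O)(=O)c3cccc(Cl)c3)cc2c1C` with 57300 nM. The steps of a 1.1-fold higher number from compound 1 to compound 3 (0.02 log units; within the scatter) and a 1.8-fold lower number from compound 2 to compound 3 (0.27 log units; within the scatter) both stay within the scatter, as does a 1.9-fold higher number from compound 1 to compound 2 (0.29 log units; within the scatter). Compound 4 `CCOC(=O)c1oc2ccc(NS(=O)(=O)c3ccccc3[N+](=O)[O-])cc2c1C` differs from compound 3 by the change (2-nitrophenyl in place of 4-bromophenyl on a sulfonyl sulfur). For the measured compounds named here, no measured step exchanges a halogen or methyl for a nitro group, so the three steps only show that swapping the group on the sulfonyl sulfur has so far moved the number little. Compound 4 is therefore expected to give a similar number, with the step of a 1.1-fold higher number from compound 3 to compound 4 (0.05 log units; within the scatter) estimated as small, at 35000 nM between 15000 nM and 80000 nM.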

Compound 4, half-maximal inhibitory concentration: 80400 nM
Estimate against measurement, compound 4: 2.3-fold (0.36 log units) below; the whole stated range lies below it.
By their numbers in this assay, from the lowest: compounds 1, 3, 2 and 4 (each within the scatter of the next, the first and the last beyond it).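

For the compounds shown here, on the sulfonyl sulfur, 2-nitrophenyl gives the first steps beyond the scatter (a 2.6-fold higher number from compound 3 to compound 4 (0.41 log units; beyond the scatter)) and (a 2.7-fold higher number from compound 1 to compound 4 (0.44 log units; beyond the scatter)), so this position is less indifferent to change than the earlier compounds suggested. The remaining step (a 1.4-fold higher number from compound 2 to compound 4 (0.15 log units; within the scatter)) stays within the scatter, so the shift does not hold against every compound. No evidence is available to explain the shift. Still open, on these data alone, is whether the nitro group counts by itself or by where it sits on the ring, and what an amine or a carboxylic acid on that ring would do.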